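This account rests on a few compounds, and the source may have more. Where it says the series, first, only, none or still open, it means among the compounds named here.

Compound 1 `CCCS(=O)(=O)Nc1ccc(Cl)c(C(=O)Nc2cnc3[nH]nc(OC)c3c2)c1F`: in a physicochemical assay for solubility, at pH 6.5 (a lower number here means a less soluble compound, a higher number a more soluble compound), compound 1 gives < 1 ug/mL, which is a limit of the assay and not a number.
Compound 2 `CCCS(=O)(=O)Nc1ccc(F)c(C(=O)Nc2cnc3[nH]nc(C4CC4)c3c2)c1F`: in this assay compound 2 gives 1 ug/mL.
Compound 3 `CCCS(=O)(=O)Nc1ccc(F)c(C(=O)Nc2cnc3[nH]nc(C4CC4)c3c2)c1Cl`: in this assay compound 3 gives 54 ug/mL.

Compound 3 stands highest of the two numbers shown, with compound 2 as its nearest neighbour. For the measured compounds named here, the one measured step, a 54-fold higher number from compound 2 to compound 3 (1.73 log units; beyond the scatter), comes from chloro in place of fluoro on an aromatic carbon. Compound 4 `CC(C)CS(=O)(=O)Nc1ccc(F)c(C(=O)Nc2cnc3[nH]nc(C4CC4)c3c2)c1Cl` differs from compound 3 by methyl in place of hydrogen on a saturated chain carbon bound to two saturated chain carbons, on a saturated chain carbon bound to two saturated chain carbons. Going by the values given here, no measured step touches this part of the molecule, and the step that was measured concerns an aromatic position, so it does not bear on this change. The expectation therefore rests on compound 3 alone and on the small size of the added group. Compound 4 is expected to give about 30 ug/mL, in a range from 8 ug/mL to 120 ug/mL. This expectation amounts to a step of a 1.8-fold lower number from compound 3 to compound 4 (0.26 log units; within the scatter), which is not expected to go beyond the scatter with any confidence.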

Compound 4, solubility: 1 ug/mL
The estimate for compound 4 lay 30-fold (1.48 log units) above the measured number; measured number below the stated range.
By their numbers in this assay, from the lowest: compounds 2 and 4 (each within the scatter of the next); then compound 3.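

The change from propylsulfonyl to isobutylsulfonyl gives a 54-fold lower number from compound 3 to compound 4 (1.73 log units; beyond the scatter) in this assay, so the sulfonyl chain proves to be a place where a single added methyl matters. That step is of the same printed size as the only earlier one, a 54-fold higher number from compound 2 to compound 3 (1.73 log units; beyond the scatter), which concerned chloro in place of fluoro on an aromatic carbon. The read-out ends not far under compound 4, as compound 1 gives a limit of the assay and not a number: the limit of < 1 ug/mL in this assay, at which 1 of the 4 values shown sits.

The compounds shown leave open whether the loss follows from the branch itself or from the added carbon, which a straight butyl chain or a cyclopropyl group at this place could separate. They also leave open how a chain bearing an amine or a hydroxyl group would read.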